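One Methyl on a Phenol Oxygen: Expecting Little Change

The compounds below may be only part of what the source reports. "The series", "measured", "known", "first", "only" and "open" are said of these compounds alone.

Compound 1 `COc1cc2c(cc1OC)C(=O)[C@@H](O)[C@H](c1cccc(O)c1O)O2` gives > 100000 nM in a functional assay on RAW264.7 cells (Rattus norvegicus) for inhibition, with RAW264.7 (Mus musculus) as the target, read by Griess assay, with stated times of 2 h and 16 h (a lower number here means a stronger inhibitor, a higher number a weaker inhibitor), which is a limit of the assay rather than a number.
Compound 2 `O=C1c2ccc(O)cc2O[C@@H](c2cccc(O)c2O)[C@@H]1O` gives > 100000 nM, again a limit.
Compound 3 `O=C1c2ccc(O)cc2O[C@H](c2cccc(O)c2O)[C@H]1O` gives 70700 nM.

Compound 2 therefore stands at the limit shared with compound 1 (the limit of > 100000 nM in this assay, at which 2 of the 3 values shown sit), while compound 3 alone has a number. Within the data shown here, the only measured step, an at least 1.4-fold lower number from compound 2 to compound 3 (0.15 log units; that floor lies within the scatter), concerns configuration alone the fact that compounds 2 and 3 differ only in the configuration as drawn and says nothing about a substituent change. Compound 4 `COc1ccc2c(c1)O[C@@H](c1cccc(O)c1O)[C@H](O)C2=O` differs from compound 2 by methyl in place of hydrogen on an oxygen on an aromatic ring. Among the measured compounds shown here, no measured pair carries this change; compound 1, which also bears methoxy in place of hydroxy, sits at the limit too. The step expected in this assay, a step that the limit leaves unreadable from compound 2 to compound 4, is none beyond the scatter. Compound 4 is expected to give about 150000 nM, between 60000 nM and 400000 nM.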

Compound 4, half-maximal inhibitory concentration: 30300 nM
Estimate against measurement, compound 4: 5.0-fold (0.69 log units) above; the whole stated range lies above it.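

In this assay, this oxygen on the aromatic ring accepts a methyl and the compound gains measurable activity, with hydroxy changed to methoxy bringing an at least 3.3-fold lower number from compound 2 to compound 4 (0.51 log units; beyond the scatter). The methoxy of compound 1 on an aromatic carbon matters too, since hydrogen in its place brings an at least 3.3-fold lower number from compound 1 to compound 4 (0.51 log units; beyond the scatter). Both steps give only a smallest possible size, because compounds 1 and 2 each stand at a limit: the limit of > 100000 nM in this assay, at which 2 of the 4 values shown sit.

Going by these compounds, how far this gain extends remains open. An ethyl or a longer chain on this oxygen, or an amine in its place, could read out quite differently.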